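A few compounds are considered here, and "the series" means these few. Any claim that something is new, unique, unknown or untested is made for them only; others in the source may bear on it.

The compounds share one core, seen in compound 1 `Nc1cc(N)c2nc(-c3ccccc3)c(Oc3ccc(Cl)c(Cl)c3)nc2c1`, and differ in the group placed on an aromatic carbon of a six-membered aromatic ring with 2 nitrogen, next to the ring nitrogen and ortho to a phenyl group. In a functional assay on NCI-H322M cells (Homo sapiens) for inhibition, read by sulforhodamine B assay, with a stated time of 48 h (on this read-out higher numbers stand for lower toxicity in this test and lower numbers for higher toxicity in this test), compound 1 gives only a limit, < 100000 nM. Compound 2 `CCOC(=O)[C@H](CCC(=O)O)NC(=O)c1ccc(Sc2nc3cc(N)cc(N)c3nc2-c2ccccc2)cc1` likewise gives only a limit in this assay, < 100000 nM. Compound 3 `Nc1cc(N)c2nc(-c3ccccc3)c(Sc3ccc(F)cc3)nc2c1` gives a readable 70800 nM in this assay. The step that the limit leaves unreadable from compound 1 to compound 3 cannot be sized because the limit of < 100000 nM in this assay, at which 2 of the 3 values shown sit, is a limit and not a number. Compound 4 `Nc1cc(N)c2nc(-c3ccccc3)c(Sc3ccc(Cl)c(Cl)c3)nc2c1` differs from compound 1 by (3,4-dichlorophenyl)sulfanyl in place of 3,4-dichlorophenoxy on an aromatic carbon. No measured step bears on this change alone, so no direction beyond the scatter can be read from the data; the readable value of compound 3, 70800 nM, is the nearest anchor for a compound of this kind in this assay. Compound 4 is therefore expected to give 50000 nM, within 15000 nM to 100000 nM, which means an expected step that the limit leaves unreadable from compound 1 to compound 4.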

Compound 4, concentration lethal to 50% of the cells: < 100000 nM
Compound 4 gave a limit, no number; the forecaster's own chance of this, stated with the estimate: 35%; the middle value does not contradict the limit.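

Compound 4 gives only a limit in this assay, so no new step can be read, neither from compound 1 nor from compound 3: the limit of < 100000 nM in this assay, at which 3 of the 4 values shown sit.

As far as these compounds go, whether (3,4-dichlorophenyl)sulfanyl differs from 3,4-dichlorophenoxy in this test stays open, as does how 3,4-dichlorophenyl compares with 4-fluorophenyl on the sulfur.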